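Chain length on the amide side of the thiazolidine series

The compounds below may be only part of what the source reports. "The series", "measured", "known", "first", "only" and "open" are said of these compounds alone.

Compound 1 `CCCCCCCCCCCCNC(=O)[C@@H]1CSC(c2cc(OC)c(OC)c(OC)c2)N1`: 2400 nM
Compound 2 `CCCCCCCCCCCCCCNC(=O)[C@@H]1CSC(c2cc(OC)c(OC)c(OC)c2)N1`: 1600 nM
Compound 3 `CCCCCCCCCCCCNC(=O)[C@@H]1CSC(c2ccc(OC)c(OC)c2)N1`: 1600 nM

In a functional assay on WM164 cells (Homo sapiens) for antiproliferative activity, read by sulforhodamine B assay, with a stated time of 48 h (on this read-out lower numbers stand for stronger inhibition and higher numbers for weaker inhibition), compound 3 gives 1600 nM, level with compound 2 at the digits shown and together with it the lowest of the three numbers; the remaining step is a 1.5-fold lower number from compound 1 to compound 3 (0.18 log units; within the scatter), so the three values sit close together.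

Compound 4 `CCCCCCCCCCCCCCCCNC(=O)[C@@H]1CSC(c2ccc(OC)c(OC)c2)N1` is compound 3 with a longer chain: butyl in place of hydrogen on a saturated chain carbon, ten or more bonds along the chain from an amide-type nitrogen. For the measured compounds named here, the one measured step that bears on this change is a 1.5-fold lower number from compound 1 to compound 2 (0.18 log units; within the scatter), a lengthening of the same chain at the same place, on the other aromatic pattern. It stayed within the scatter. Going by the values given here, nothing measured shows what a longer extension does, and only one such step exists, so the expectation rests on that single comparison.

Compound 4 is therefore expected to stay close to compound 3, with a step of about a 1.3-fold lower number from compound 3 to compound 4 (0.12 log units; within the scatter) as the estimate, toward a lower number if anything but not beyond the scatter. The estimated value for compound 4 is 1200 nM, in the range 600 nM to 2600 nM.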

Compound 4, half-maximal inhibitory concentration: 500 nM
Compound 4: the middle estimate sits 2.4-fold (0.38 log units) above what was measured; measured number outside the range, below it.
By their numbers in this assay, from the lowest: compound 4; then compounds 2, 3 and 1 (each within the scatter of the next).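

In this assay, for the compounds shown here, butyl in place of hydrogen on a saturated chain carbon, ten or more bonds along the chain from an amide-type nitrogen, gives a 3.2-fold lower number from compound 3 to compound 4 (0.51 log units; beyond the scatter), the only step in this set beyond the scatter, whereas the ethyl extension gave a 1.5-fold lower number from compound 1 to compound 2 (0.18 log units; within the scatter) and stayed within it. Chain length at this position can therefore move the number, at least on the aromatic pattern of compound 3, though the two extensions differ in size and sit on different aromatic patterns. Nothing available accounts for the step.

From the compounds shown here alone, whether the same butyl extension has a comparable effect on the aromatic pattern of compound 1 remains open. Also open, going by these compounds, is whether a still longer chain, or an amine or carboxylic acid at the chain end, would keep, extend or lose the step.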